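The source may hold more compounds than are shown below. What is called first, only, known or untested is meant among the compounds shown, and "the series" means these compounds.

Working notes on the urea series. In an assay on CHO-K1 cells for antagonist activity at transient receptor potential cation channel subfamily V member 1 (Homo sapiens), read by FLIPR and calcium flux, with a stated time of 6 min (on this read-out higher numbers stand for weaker inhibition and lower numbers for stronger inhibition), compound 1 `O=C(NCc1cc(C(F)(F)F)nn1-c1cccc(Cl)c1)Nc1cccc2[nH]ncc12` gives 0.9 nM. Among the measured compounds shown here, compound 2 `Cn1ncc2c(NC(=O)NCc3cc(C(F)(F)F)nn3-c3cccc(Cl)c3)cccc21` carries a methyl on the aromatic nitrogen of the same core, and in this assay compound 2 gives 2.3 nM; the step of a 2.6-fold higher number from compound 1 to compound 2 (0.41 log units; beyond the scatter) is the only measured instance of this change. Compound 3 `CC(C)(C)c1cc(CNC(=O)Nc2cccc3[nH]ncc23)n(-c2cccc(Cl)c2)n1` carries tert-butyl in place of trifluoromethyl and in this assay compound 3 gives 0.6 nM; the step of a 1.5-fold lower number from compound 1 to compound 3 (0.18 log units; within the scatter) is small. Compound 3 thus sits at the low end of the three numbers, within the scatter of compound 1 and beyond that of compound 2.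

Compound 4 `Cn1ncc2c(NC(=O)NCc3cc(C(C)(C)C)nn3-c3cccc(Cl)c3)cccc21` differs from compound 3 by methyl in place of hydrogen on an aromatic nitrogen, the same change seen between compound 1 and compound 2. The step of a 2.6-fold higher number from compound 1 to compound 2 (0.41 log units; beyond the scatter) is therefore the one that bears on it, and a step of about that size, towards a higher number, is expected: a 2.7-fold higher number from compound 3 to compound 4 (0.43 log units; beyond the scatter). Compound 4 is accordingly estimated at 1.6 nM, with a range from 0.8 nM to 3.2 nM.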

Compound 4, inhibition constant: 0.4 nM
Estimate against measurement, compound 4: 4.0-fold (0.60 log units) above; the whole stated range lies above it.
By their numbers in this assay, from the lowest: compounds 4, 3 and 1 (each within the scatter of the next, the first and the last beyond it); then compound 2.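

Methyl on the aromatic nitrogen, the change from 1H-indazol-4-yl to 1-methyl-1H-indazol-4-yl, does not give one fixed step in the series: with tert-butyl on the other ring, the result is a 1.5-fold lower number from compound 3 to compound 4 (0.18 log units; within the scatter), so the rise seen with trifluoromethyl does not carry over: the same change on two cores in this assay, a 2.6-fold higher number (0.41 log units; beyond the scatter) from compound 1 to compound 2 and a 1.5-fold lower number (0.18 log units; within the scatter) from compound 3 to compound 4, 3.8-fold (0.58 log units) apart, beyond the scatter of two such steps. Read the other way, tert-butyl in place of trifluoromethyl also depends on what sits on that nitrogen, with a clear step only when methyl is present, a 5.8-fold lower number from compound 2 to compound 4 (0.76 log units; beyond the scatter): the same change on two cores in this assay, a 1.5-fold lower number (0.18 log units; within the scatter) from compound 1 to compound 3 and a 5.8-fold lower number (0.76 log units; beyond the scatter) from compound 2 to compound 4, 3.8-fold (0.58 log units) apart, beyond the scatter of two such steps. The two changes are therefore not additive across these four compounds, and both gaps rest on the same four values.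

On these data alone, whether the nitrogen accepts more than methyl remains open, for instance ethyl, a longer chain, or a chain ending in an amine or a carboxylic acid. Also open, as far as these compounds go, is whether cyclopropyl in place of tert-butyl would show the same dependence.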